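Phenyl substituent changes on the shared core

The compounds below may be only part of what the source reports. "The series", "measured", "known", "first", "only" and "open" are said of these compounds alone.

Measured so far:
compound 1 `COc1cccc(/C=N/Nc2ncc3c(n2)n(C2CCCC2)c(=O)c(=O)n3C)c1`: 20700 nM
compound 2 `COc1ccc(/C=N/Nc2ncc3c(n2)n(C2CCCC2)c(=O)c(=O)n3C)cc1`: 26300 nM

In a functional assay on PC-3 cells (Homo sapiens) for antiproliferative activity, read by MTT assay (a lower number here means a stronger inhibitor, a higher number a weaker inhibitor), compound 1 gives 20700 nM and compound 2 gives 26300 nM. Compound 2 holds the highest of the two numbers; its nearest neighbour is compound 1, and the step of a 1.3-fold higher number from compound 1 to compound 2 (0.10 log units; within the scatter) lies within the scatter, so no order between the two is claimed.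

Compound 3 `Cn1c(=O)c(=O)n(C2CCCC2)c2nc(N/N=C/c3ccc(O)c(Br)c3)ncc21` is not yet measured. It differs from compound 2 by 3-bromo-4-hydroxyphenyl in place of 4-methoxyphenyl on a carbon with a double bond to nitrogen. Among the measured compounds shown here, no measured step bears directly on this change: the single recorded step, a 1.3-fold higher number from compound 1 to compound 2 (0.10 log units; within the scatter), exchanges 3-methoxyphenyl for 4-methoxyphenyl and stays within the scatter, which says nothing about replacing a methoxy group with a bromine and a hydroxyl. The expected step of a 1.2-fold lower number from compound 2 to compound 3 (0.08 log units; within the scatter) is therefore none beyond the scatter, with wide uncertainty around it. Compound 3 is estimated at 22000 nM, in a range from 6000 nM to 70000 nM.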

Compound 3, half-maximal inhibitory concentration: 11600 nM
Estimate against measurement, compound 3: 1.9-fold (0.28 log units) above; measured number inside the range.
By their numbers in this assay, from the lowest: compounds 3, 1 and 2 (each within the scatter of the next, the first and the last beyond it).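

In this assay, among the compounds shown here, the group on the carbon with a double bond to nitrogen now gives the first step beyond the scatter: 3-bromo-4-hydroxyphenyl in place of 4-methoxyphenyl gives a 2.3-fold lower number from compound 2 to compound 3 (0.36 log units; beyond the scatter), a modest change. In place of 3-methoxyphenyl, the same group gives a 1.8-fold lower number from compound 1 to compound 3 (0.25 log units; within the scatter), which stays within the scatter, so compound 3 separates from compound 2 but not from compound 1. No available measurement accounts for the step.

As far as these compounds go, it remains open whether the bromine or the hydroxyl carries the step, since both enter together in compound 3. Also open, from the compounds shown here alone, is how this position would read with an amine or a carboxylic acid on the phenyl ring.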